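Furan for thiophene on the aryl substituent of the core

The source may hold more compounds than are shown below. What is called first, only, known or untested is meant among the compounds shown, and "the series" means these compounds.

Among the compounds with values here, compound 3 `COc1ccc(S(=O)(=O)N2CCc3cccc(-c4cccs4)c32)cc1` gives 251 nM in a functional assay on KB-VIN10 cells (Homo sapiens) for inhibition, with a stated time of 72 h (a lower number here means a stronger inhibitor, a higher number a weaker inhibitor), the second highest of the three numbers so far. Compound 1 `COc1ccc(S(=O)(=O)N2CCc3cccc(-c4cccnc4)c32)cc1` gives 84.5 nM and compound 2 `COc1ccc(-c2cccc3c2N(S(=O)(=O)c2ccc(OC)cc2)CC3)cc1` gives 352 nM in this assay. The steps among them stay modest: a 3.0-fold higher number from compound 1 to compound 3 (0.47 log units; beyond the scatter) and a 4.2-fold higher number from compound 1 to compound 2 (0.62 log units; beyond the scatter), whereas a 1.4-fold lower number from compound 2 to compound 3 (0.15 log units; within the scatter), so compound 2 and compound 3 cannot be ordered.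

Compound 4 `COc1ccc(S(=O)(=O)N2CCc3cccc(-c4ccco4)c32)cc1` carries furan-2-yl in place of thiophen-2-yl on an aromatic carbon. Within the data shown here, no measured pair exchanges one five-membered heteroaryl for another; the only steps that touch this position swap pyridin-3-yl or 4-methoxyphenyl for thiophen-2-yl, and the latter swap sat within the scatter. The change from thiophen-2-yl to furan-2-yl keeps the same count of ring atoms and the same single acceptor, so no step beyond the scatter is expected in this assay, in either direction.

Compound 4 is therefore estimated at 280 nM, with a range of 120 nM to 650 nM, meaning an expected 1.1-fold higher number from compound 3 to compound 4 (0.05 log units; within the scatter).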

Compound 4, half-maximal inhibitory concentration: 79.2 nM
Beside the measured number, compound 4's estimate is 3.5-fold (0.55 log units) above it; measured number outside the range, below it.
By their numbers in this assay, from the lowest: compounds 4 and 1 (each within the scatter of the next); then compounds 3 and 2 (each within the scatter of the next).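

In this assay, within the data shown here, the first exchange of one five-membered heteroaryl for another on this aromatic carbon is not silent: furan-2-yl in place of thiophen-2-yl gives a step beyond the scatter (a 3.2-fold lower number from compound 3 to compound 4 (0.50 log units; beyond the scatter)), although the two groups differ only in oxygen for sulfur. Furan-2-yl also separates from 4-methoxyphenyl (a 4.4-fold lower number from compound 2 to compound 4 (0.65 log units; beyond the scatter)) but not from pyridin-3-yl (a 1.1-fold lower number from compound 1 to compound 4 (0.03 log units; within the scatter)), so the four groups now fall into two sets, compounds 1 and 4 with the lower numbers and compounds 2 and 3 with the higher. No measurement on hand explains the gap between the furan and thiophene compounds.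

Open, from the compounds shown here alone, is how a ring with a second hetero atom, such as thiazol-2-yl, or a non-aromatic group such as aminomethyl, would read on this carbon. Also open, going by these compounds, is whether the furan-for-thiophene step persists when the 4-methoxyphenyl on the sulfonyl is replaced by another aryl group.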